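Bromo-methoxy-hydroxyphenyl swap in compound 2: working notes

A few compounds are considered here, and "the series" means these few. Any claim that something is new, unique, unknown or untested is made for them only; others in the source may bear on it.

In a functional assay on MCF7 cells (Homo sapiens) for antiproliferative activity, read by sulforhodamine B assay, with a stated time of 48 h (on this read-out higher numbers stand for weaker inhibition and lower numbers for stronger inhibition), compound 1 `COc1cccc(C=C(C(=O)/C=C/c2cccc(OC)c2OC)C(=O)/C=C/c2cccc(OC)c2OC)c1OC` gives 520 nM and compound 2 `COc1cccc(/C=C/C(=O)C(=Cc2ccc(O)c(F)c2)C(=O)/C=C/c2cccc(OC)c2OC)c1OC` gives 300 nM, so the two stand within the scatter of each other. Compound 3 `COc1cc(C=C(C(=O)/C=C/c2cccc(OC)c2OC)C(=O)/C=C/c2cccc(OC)c2OC)cc(Br)c1O` carries 3-bromo-4-hydroxy-5-methoxyphenyl in place of 3-fluoro-4-hydroxyphenyl on a double-bonded chain carbon bound to a double-bonded chain carbon. Among the compounds with values here, only one measured step bears on this place, a 1.7-fold lower number from compound 1 to compound 2 (0.24 log units; within the scatter), and it stayed within the scatter. No step beyond the scatter is therefore expected in this assay, and the estimated step is a 1.2-fold higher number from compound 2 to compound 3 (0.07 log units; within the scatter). The estimate for compound 3 is 350 nM, with an expected range of 130 nM to 950 nM.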

Compound 3, half-maximal inhibitory concentration: 360 nM
Compound 3: the middle estimate sits 1.0-fold (0.01 log units) below what was measured; low and high end bracket the measured number.
By their numbers in this assay, from the lowest: compounds 2, 3 and 1 (each within the scatter of the next).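

In this assay, 3-bromo-4-hydroxy-5-methoxyphenyl on a double-bonded chain carbon bound to a double-bonded chain carbon replaces 3-fluoro-4-hydroxyphenyl with a 1.2-fold higher number from compound 2 to compound 3 (0.08 log units; within the scatter) and replaces 2,3-dimethoxyphenyl with a 1.4-fold lower number from compound 1 to compound 3 (0.16 log units; within the scatter). Among compounds 1, 2 and 3, no step at this place lies beyond the scatter, now also with a group carrying bromine and a further methoxy. No available evidence bears on this result.

Going by these compounds, whether an amine or a carboxylic acid at this place would give a step beyond the scatter remains open.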